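This account rests on a few compounds, and the source may have more. Where it says the series, first, only, none or still open, it means among the compounds named here.

Compound 1 `O=S(=O)(NCCCCNCc1ccc(Br)cc1)c1cc(C(F)(F)F)cc(C(F)(F)F)c1`: 2200 nM
Compound 2 `O=S(=O)(NCCCNCc1ccc(Cl)c(C(F)(F)F)c1)c1cc(C(F)(F)F)cc(C(F)(F)F)c1`: 10000 nM
Compound 3 `O=S(=O)(NCCCNCc1ccccc1)c1cc(C(F)(F)F)cc(C(F)(F)F)c1`: 16000 nM

In a functional assay on PANC-1 cells (Homo sapiens) for inhibition, read by MTT assay, with a stated time of 72 h (a higher number here means a weaker inhibitor of growth, a lower number a stronger inhibitor of growth), compound 3 gives the highest of the three numbers, though compound 2 lies within the scatter of it; compound 1 stands apart by a 7.3-fold higher number from compound 1 to compound 3 (0.86 log units; beyond the scatter). Compound 4 `COc1cccc(CNCCCNS(=O)(=O)c2cc(C(F)(F)F)cc(C(F)(F)F)c2)c1` differs from compound 3 by methoxy in place of hydrogen on an aromatic carbon. Going by the values given here, two measured steps touch the benzyl part. The step of a 1.6-fold higher number from compound 2 to compound 3 (0.20 log units; within the scatter) shows that substituents placed on that ring changed little. The step of a 7.3-fold higher number from compound 1 to compound 3 (0.86 log units; beyond the scatter) is larger, but it joins a different chain with a change on the ring, so it cannot be read as the ring alone. A step of a 1.3-fold lower number from compound 3 to compound 4 (0.12 log units; within the scatter) is therefore expected, within the scatter. Compound 4 is estimated at 12000 nM, between 5000 nM and 30000 nM.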

Compound 4, concentration for 50% growth inhibition: 10000 nM
For compound 4 the middle estimate is 1.2-fold (0.08 log units) above the measured one; the measured number falls inside the stated range.
By their numbers in this assay, from the lowest: compound 1; then compounds 2, 4 and 3 (each within the scatter of the next).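

In this assay, methoxy in place of hydrogen on the aromatic carbon gives a 1.6-fold lower number from compound 3 to compound 4 (0.20 log units; within the scatter) and so leaves the number where the unsubstituted ring had it. Between the two substituted rings there is no change at the digits printed from compound 2 to compound 4 (within the scatter), so 3-methoxyphenyl and 4-chloro-3-(trifluoromethyl)phenyl cannot be told apart here. The larger 4.5-fold higher number from compound 1 to compound 4 (0.66 log units; beyond the scatter) also joins a different chain, so it cannot be read as the ring alone.

As far as these compounds go, whether a hydroxyl or a nitrile on this ring, or 3-methoxybenzyl on the longer chain of compound 1, would shift the number remains open. Nothing measured here accounts for these numbers.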